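A few compounds are considered here, and "the series" means these few. Any claim that something is new, unique, unknown or untested is made for them only; others in the source may bear on it.

The compounds measured so far in an ADME assay on HepG2 cells (Homo sapiens) for cytotoxicity, read by CellTiter-Glo and ATP content, with a stated time of 72 h; a lower number here means that less compound is needed, a higher number that more compound is needed for the effect:

Compound 1 `CN(Cc1ccccc1)C(=O)C1CCN(C(=O)c2ccc(S(C)(=O)=O)c([N+](=O)[O-])c2)CC1`. In this assay compound 1 gives > 27000 nM, which is a limit of the assay rather than a number.
Compound 2 `CS(=O)(=O)c1ccc(C(=O)NCC(=O)N(Cc2ccccc2)Cc2ccccc2)cc1[N+](=O)[O-]`. In this assay compound 2 gives 11900 nM.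
Compound 3 `CN(Cc1ccccc1)C(=O)CNC(=O)c1ccc(S(C)(=O)=O)c([N+](=O)[O-])c1`. In this assay compound 3 gives > 27000 nM, again a limit of the assay and not a number.

Compound 2 and compound 3 share a core and differ in one place: phenyl in place of hydrogen on a saturated chain carbon bound to an amide-type nitrogen. This change produced an at least 2.2-fold lower number from compound 3 to compound 2 (0.35 log units; beyond the scatter). The difference between the core of compound 1 and the core of compound 3 is not broken down here.

Compound 4 `CS(=O)(=O)c1ccc(C(=O)N2CCC(C(=O)N(Cc3ccccc3)Cc3ccccc3)CC2)cc1[N+](=O)[O-]` has not yet been measured. It stands to compound 1 as compound 2 stands to compound 3, with the same change at the same place: phenyl in place of hydrogen on a saturated chain carbon bound to an amide-type nitrogen. Because compound 1 and compound 3 both sit at the limit of > 27000 nM in this assay, at which 2 of the 3 values shown sit, the starting point of this second step is known only as a limit. If the step repeats what was seen from compound 3 to compound 2, compound 4 is expected to show an at least 1.9-fold lower number from compound 1 to compound 4 (0.28 log units; that floor lies within the scatter). Compound 4 is therefore estimated at 14000 nM, with a likely range from 5000 nM to 30000 nM, and a real chance that this assay again reports only a limit.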

Compound 4, half-maximal effective concentration: > 27000 nM
Compound 4 ended at the assay's limit; the forecaster's own chance of this, stated with the estimate: 40%; middle value at least 1.9-fold (0.28 log units) away from the limit.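

No size can be read for the step between compound 1 and compound 4, because both compounds stand at the same limit: the limit of > 27000 nM in this assay, at which 3 of the 4 values shown sit.

Still open, on these data alone, is whether phenyl in place of hydrogen on a saturated chain carbon bound to an amide-type nitrogen lowers the number at all on the core of compound 1.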